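The source may report more compounds than this note shows. Statements on the series, on what has been measured and on what is new or still open speak of the compounds shown alone.

Measured so far:
Compound 1 `Cc1ccc(-c2nn(-c3ccccc3)cc2-c2nc3ccccc3n2S(=O)(=O)c2ccccc2)cc1`: 820 nM
Compound 2 `Cc1ccc(-c2nn(-c3ccccc3)cc2-c2nc3ccccc3n2S(=O)(=O)c2ccc(Br)cc2)cc1`: 2340 nM

In a functional assay on HeLa cells (Homo sapiens) for antiproliferative activity, read by MTT assay, with a stated time of 24 h (on this read-out higher numbers stand for weaker inhibition and lower numbers for stronger inhibition), compound 2 gives 2340 nM, the higher of the two numbers and thus the weaker inhibition of the pair. Compound 3 `Cc1ccc(-c2nn(-c3ccccc3)cc2-c2nc3ccccc3n2S(=O)(=O)c2ccc(C(F)(F)F)cc2)cc1` has not yet been measured. It carries trifluoromethyl in place of bromo on an aromatic carbon, para to a large group: trifluoromethyl in place of bromo on an aromatic carbon. For the measured compounds named here, only one measured step bears on this change: a 2.9-fold higher number from compound 1 to compound 2 (0.46 log units; beyond the scatter), a modest step that comes with bromo in place of hydrogen. Going by the values given here, no measured compound carries trifluoromethyl, so the data give no direction for the swap, and compound 3 is expected to stay close to compound 2 at 2340 nM. The expected step is a 1.2-fold lower number from compound 2 to compound 3 (0.07 log units; within the scatter), which would not lie beyond the scatter. For compound 3 the estimated value is 2000 nM, with an expected range from 800 nM to 5000 nM.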

Compound 3, half-maximal inhibitory concentration: 1520 nM
Compound 3: the middle estimate sits 1.3-fold (0.12 log units) above what was measured; low and high end bracket the measured number.
By their numbers in this assay, from the lowest: compounds 1, 3 and 2 (each within the scatter of the next, the first and the last beyond it).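

In this assay a second group can now be read on an aromatic carbon of a six-membered aromatic ring of carbon only, para to a large group. Trifluoromethyl in place of bromo gives a 1.5-fold lower number from compound 2 to compound 3 (0.19 log units; within the scatter) and so does not set the two groups apart at this place. Trifluoromethyl in place of hydrogen gives a 1.9-fold higher number from compound 1 to compound 3 (0.27 log units; within the scatter) whereas bromo in place of hydrogen gives a 2.9-fold higher number from compound 1 to compound 2 (0.46 log units; beyond the scatter) so only bromo separates from hydrogen here, and nothing given speaks to a reason for these numbers.

From the compounds shown here alone, whether an amine, a carboxylic acid or a methoxy group at this place would shift the number beyond the scatter remains open. So does whether bromo and trifluoromethyl would read alike on another aromatic carbon of the same ring.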